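Methoxy to Hydroxy on a Shared Anilino Core

The source may report more compounds than this note shows. Statements on the series, on what has been measured and on what is new or still open speak of the compounds shown alone.

Compound 1 `Cc1ccccc1Nc1ccc2c(c1)C(=O)N(C1CCC(=O)NC1=O)C2=O`: 2%
Compound 2 `COc1ccc(Nc2ccc3c(c2)C(=O)N(C2CCC(=O)NC2=O)C3=O)cc1`: 29%
Compound 3 `CCCc1ccc(Nc2cccc3c2C(=O)N(C2CCC(=O)NC2=O)C3=O)cc1`: 23%

In an assay on FRT-Jurkat cells for inhibition of nuclear factor NF-kappa-B complex (Homo sapiens), read by flow cytometry, with a stated time of 24 h, tested at 10 uM (on this read-out higher numbers stand for more inhibition at the one concentration tested (going by the name of the read-out) and lower numbers for less inhibition), compound 2 gives 29%, a number that none of the other two exceeds. Compound 3, with 23%, cannot be told apart from compound 2 within the scatter, while compound 1, with 2%, sits clearly beyond it. For the measured compounds named here, the only single change measured so far is the step of a number 27 percentage points higher from compound 1 to compound 2 (beyond the scatter), a modest rise that comes with the exchange of 2-methylphenyl for 4-methoxyphenyl on the nitrogen.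

Compound 4 `O=C1CCC(N2C(=O)c3ccc(Nc4ccc(O)cc4)cc3C2=O)C(=O)N1` differs from compound 2 by hydrogen in place of methyl on an oxygen on an aromatic ring, that is, methoxy becomes hydroxy on the 4-substituted phenyl ring. Going by the values given here, no measured step touches this particular change, and the one step recorded concerns a different substituent pattern, so it gives no direct guide. Without such a guide, the step of a number 1 percentage points lower from compound 2 to compound 4 (within the scatter) is expected to stay within the scatter. Compound 4 is therefore estimated at 28%, with a range from 8% to 48%.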

Compound 4, a percentage reported as inhibition, at one concentration (the size of the read-out at that concentration, not a potency): 4%
Compound 4: the middle estimate sits 24 percentage points above what was measured; the whole stated range lies above it.
By their numbers in this assay, from the lowest: compounds 1 and 4 (each within the scatter of the next); then compounds 3 and 2 (each within the scatter of the next).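

In this assay, the methyl on the oxygen matters: losing it gives a number 25 percentage points lower from compound 2 to compound 4 (beyond the scatter), so methoxy to hydroxy on the aromatic ring is the only single change shown that lowers the read-out. The step of a number 2 percentage points higher from compound 1 to compound 4 (within the scatter) puts 4-hydroxyphenyl on the nitrogen level with 2-methylphenyl, so the rise seen with 4-methoxyphenyl does not simply come with any 4-substituted phenyl on that nitrogen, and among these compounds it goes with the methoxy group. Nothing in the data given explains why removing one methyl has this effect.

As far as these compounds go, whether a longer ether such as ethoxy, or an amine in place of the methoxy group, would keep the read-out of compound 2 stays open. So does whether methoxy to hydroxy would act the same way on the core of compound 3.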